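Swapping the aryl group on the hydrazone: compound 3 to compound 4

The source may report more compounds than this note shows. Statements on the series, on what has been measured and on what is new or still open speak of the compounds shown alone.

Compound 1, `COc1ccc(OC)c(/C=N/NC(=O)Nc2ccc(Oc3ccnc(-c4nncn4CCN(C)C)c3)c(F)c2)c1`, in a functional assay on HT-29 cells (Homo sapiens) for cytotoxicity, read by MTT assay, with a stated time of 72 h (a lower number here means a stronger inhibitor, a higher number a weaker inhibitor), compound 1 gives 2070 nM.
Compound 2, `CN(C)CCn1cnnc1-c1cc(Oc2ccc(NC(=O)N/N=C/c3ccccc3O[N+](=O)[O-])cc2F)ccn1`, in this assay compound 2 gives 950 nM.
Compound 3, `COc1cc(/C=N/NC(=O)Nc2ccc(Oc3ccnc(-c4nncn4CCN(C)C)c3)c(F)c2)ccc1O`, in this assay compound 3 gives 120 nM.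

All three share one core and differ only in the aryl group on a carbon with a double bond to nitrogen. Compound 3 has the lowest number of the three: a 17-fold lower number from compound 1 to compound 3 (1.24 log units; beyond the scatter), and a 7.9-fold lower number from compound 2 to compound 3 (0.90 log units; beyond the scatter). Compound 4, `CN(C)CCn1cnnc1-c1cc(Oc2ccc(NC(=O)N/N=C/c3ccc(O)cc3O)cc2F)ccn1`, keeps that core and changes the same group again: 2,4-dihydroxyphenyl in place of 4-hydroxy-3-methoxyphenyl on a carbon with a double bond to nitrogen.

For the measured compounds named here, the steps that bear on this are the two that end at compound 3, since each also exchanges the aryl group at that place; both were beyond the scatter, one large and one modest, and both favoured the 4-hydroxy-3-methoxyphenyl. Going by the values given here, no measured compound carries a 2,4-dihydroxyphenyl, so the new step cannot be read off directly. Because a 7.9-fold lower number from compound 2 to compound 3 (0.90 log units; beyond the scatter) and a 17-fold lower number from compound 1 to compound 3 (1.24 log units; beyond the scatter) both gave a lower number when the 4-hydroxy-3-methoxyphenyl entered, a modest rise is expected for compound 4 when that group leaves, with wide uncertainty: a 2.9-fold higher number from compound 3 to compound 4 (0.46 log units; beyond the scatter). Compound 4 is estimated at 350 nM, within 90 nM to 1400 nM.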

Compound 4, half-maximal inhibitory concentration: 52600 nM
Estimate against measurement, compound 4: 150-fold (2.18 log units) below, and the stated range ends below it.
By their numbers in this assay, from the lowest: compound 3; then compound 2; then compound 1; then compound 4.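

For the compounds shown here, this position is far less forgiving than the earlier compounds showed: in this assay there is a 440-fold higher number from compound 3 to compound 4 (2.64 log units; beyond the scatter) for a change of aryl group alone. The 2,4-dihydroxyphenyl also falls behind the two groups that had given higher numbers than compound 3, with a 55-fold higher number from compound 2 to compound 4 (1.74 log units; beyond the scatter) and a 25-fold higher number from compound 1 to compound 4 (1.41 log units; beyond the scatter) on the same shared core. Hydroxy groups on the aryl ring therefore do not settle the outcome alone, since compound 3 has the lowest number of the four and compound 4, also carrying hydroxy groups, has the highest.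

Nothing available here explains why this swap raises the number so sharply. Going by these compounds, it also remains open whether an aryl group carrying an amine or a carboxylic acid would give a number closer to that of compound 3 or that of compound 4.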